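Aryl groups on the sulfonyl sulfur: working notes

This account rests on a few compounds, and the source may have more. Where it says the series, first, only, none or still open, it means among the compounds named here.

Values in a functional assay on K562 cells (Homo sapiens) for inhibition, read by trypan blue exclusion, with a stated time of 72 h; a higher number here means a weaker inhibitor, a lower number a stronger inhibitor:
compound 1 `Cn1c(=O)c(S(=O)(=O)Cc2ccc(F)cc2F)cc2cnc(Nc3ccc4[nH]ccc4c3)nc21`: 1000 nM
compound 2 `COc1ccc(S(=O)(=O)c2cc3cnc(Nc4ccc5[nH]ccc5c4)nc3n(C)c2=O)cc1`: 300 nM
compound 3 `Cn1c(=O)c(S(=O)(=O)c2ccc([N+](=O)[O-])cc2F)cc2cnc(Nc3ccc4[nH]ccc4c3)nc21`: 200 nM

Compound 3, at 200 nM, cannot be separated from compound 2, as the data show a 1.5-fold lower number from compound 2 to compound 3 (0.18 log units; within the scatter). It stands clear of compound 1, with a 5.0-fold lower number from compound 1 to compound 3 (0.70 log units; beyond the scatter). Compound 2 also stands clear of compound 1, with a 3.3-fold lower number from compound 1 to compound 2 (0.52 log units; beyond the scatter).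

Compound 4 `Cn1c(=O)c(S(=O)(=O)c2ccc(F)cc2N)cc2cnc(Nc3ccc4[nH]ccc4c3)nc21` has not yet been measured. It keeps the shared core and differs from compound 3 only on the sulfonyl sulfur, with 2-amino-4-fluorophenyl in place of 2-fluoro-4-nitrophenyl on a sulfonyl sulfur.

Among the compounds with values here, the closest precedent is the exchange of one substituted phenyl group for another between compound 2 and compound 3, which stayed within the scatter. The two modest steps from compound 1 replace 2,4-difluorobenzyl and bear on this change less directly. Within the data shown here, that single phenyl exchange is thin evidence, and no measured compound carries the amino substituent. No step beyond the scatter is therefore expected in this assay, and the data give no firm direction.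

The estimated step is a 1.5-fold higher number from compound 3 to compound 4 (0.18 log units; within the scatter).

The estimated value for compound 4 is 300 nM, with an expected range of 100 nM to 900 nM.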

Compound 4, half-maximal inhibitory concentration: 2000 nM
For compound 4 the middle estimate is 6.7-fold (0.82 log units) below the measured one; measured number outside the range, above it.
By their numbers in this assay, from the lowest: compounds 3 and 2 (each within the scatter of the next); then compounds 1 and 4 (each within the scatter of the next).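

In this assay, the sulfonyl sulfur position proves sensitive to the choice of substituted phenyl group, which the exchange between compound 2 and compound 3 did not reveal: 2-amino-4-fluorophenyl in place of 2-fluoro-4-nitrophenyl gives a 10-fold higher number from compound 3 to compound 4 (1.00 log units; beyond the scatter), and in place of 4-methoxyphenyl it gives a 6.7-fold higher number from compound 2 to compound 4 (0.82 log units; beyond the scatter). A phenyl group on the sulfur therefore does not by itself keep the number in the range of compound 2 and compound 3, since 2-amino-4-fluorophenyl in place of 2,4-difluorobenzyl gives a 2.0-fold higher number from compound 1 to compound 4 (0.30 log units; within the scatter), leaving compound 4 inseparable from compound 1. No measured property accompanies these steps, so the data offer no account of them.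

The compounds shown leave open which part of the exchange carries the step, as 2-amino-4-fluorophenyl and 2-fluoro-4-nitrophenyl differ in more than one substituent at once. Within the data shown here, an unsubstituted phenyl group, or an acetamide in place of the amine, has no counterpart here, so the contributions of the nitro group, the amine and the fluorine remain unseparated.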